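The source may report more compounds than this note shows. Statements on the series, on what has been measured and on what is new or still open speak of the compounds shown alone.

Compound 1 `Cc1cc(C)c(-c2nc(CN3CCC(C(=O)NCCCN4C[C@H](C)C[C@H](C)C4)CC3)c(C)o2)c(C)c1` and compound 2 `Cc1cccc(Cl)c1-c1nc(CN2CCC(C(=O)NCCCN3CCC(C(C)C)CC3)CC2)c(C)o1` were both tested in an ADME assay on Huh7.5.1 cells (Homo sapiens) for cytotoxicity, read by ATP content, with a stated time of 48 h; on this read-out lower numbers stand for higher toxicity in this test and higher numbers for lower toxicity in this test. In this assay compound 1 gives 6570 nM and compound 2 gives 4910 nM; the two numbers lie within the usual scatter of each other, so neither stands apart. Compound 3 `Cc1cccc(C)c1-c1nc(CN2CCC(C(=O)NCCCN3C[C@H](C)C[C@H](C)C3)CC2)c(C)o1` differs from compound 1 by a single change: hydrogen in place of methyl on an aromatic carbon. Among the compounds with values here, no measured pair shows this change, so its effect in this assay is unknown; a step no larger than the scatter is expected, in either direction. For compound 3 the estimated value is 6000 nM, within a range from 3000 nM to 12000 nM, which means an expected step of a 1.1-fold lower number from compound 1 to compound 3 (0.04 log units; within the scatter).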

Compound 3, half-maximal cytotoxic concentration: 21000 nM
The estimate for compound 3 lay 3.5-fold (0.54 log units) below the measured number; measured number above the stated range.
By their numbers in this assay, from the lowest: compounds 2 and 1 (each within the scatter of the next); then compound 3.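

In this assay, the methyl para to a large group turns out not to be a silent feature of the ring: replacing it with hydrogen, 2,4,6-trimethylphenyl to 2,6-dimethylphenyl, gives a 3.2-fold higher number from compound 1 to compound 3 (0.50 log units; beyond the scatter), so the change goes with lower toxicity in this test. This rests on one pair of compounds, and nothing at hand explains the shift. Open, from the compounds shown here alone, is whether a chlorine, a methoxy group or an amine on this same carbon would move the number the same way, and whether the step would hold with the other side chain of compound 2.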